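This account rests on a few compounds, and the source may have more. Where it says the series, first, only, none or still open, it means among the compounds named here.

Compound 3 `CCn1c(=O)/c(=C2\Sc3ccc(C)cc3N2C)s/c1=C\c1ccncc1Nc1ccccc1F` gives 150 nM in a functional assay on CWR22R cells (Homo sapiens) for inhibition (on this read-out higher numbers stand for weaker inhibition and lower numbers for stronger inhibition), the lowest of the three numbers shown. Compound 1 `CCn1c(=O)/c(=C2\Sc3ccccc3N2C)s/c1=C\c1ccncc1Nc1ccccc1F` gives 300 nM, and the step of a 2.0-fold lower number from compound 1 to compound 3 (0.30 log units; within the scatter) stays within the scatter. Compound 2 `CCn1c(=O)/c(=C2\Sc3ccc(OC)cc3N2C)s/c1=C\c1ccncc1Nc1ccccc1Cl` gives 500 nM, which lies beyond the scatter from compound 3. Compound 4 `CCn1c(=O)/c(=C2\Sc3ccc(OC)cc3N2C)s/c1=C\c1ccncc1Nc1ccccc1F` differs from compound 3 by methoxy in place of methyl on an aromatic carbon. Going by the values given here, no measured step exchanges methyl for methoxy alone; compound 2 carries the methoxy but also chloro in place of fluoro, so its value bears only loosely on this step. Among the compounds with values here, the only step at this carbon, from hydrogen to methyl, stayed within the scatter, so nothing beyond the scatter is expected in this assay for compound 4, estimated as a 1.7-fold higher number from compound 3 to compound 4 (0.22 log units; within the scatter). Compound 4 is expected to give 250 nM, between 100 nM and 600 nM.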

Compound 4, half-maximal inhibitory concentration: 190 nM
Beside the measured number, compound 4's estimate is 1.3-fold (0.12 log units) above it; low and high end bracket the measured number.
By their numbers in this assay, from the lowest: compounds 3, 4, 1 and 2 (each within the scatter of the next, the first and the last beyond it).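

In this assay, this aromatic carbon accepts methoxy as well as methyl without a step beyond the scatter (a 1.3-fold higher number from compound 3 to compound 4 (0.10 log units; within the scatter)), and the same holds for methoxy against hydrogen (a 1.6-fold lower number from compound 1 to compound 4 (0.20 log units; within the scatter)). Fluoro in place of chloro, with the methoxy held constant, is the first single change shown to pass the scatter (a 2.6-fold lower number from compound 2 to compound 4 (0.42 log units; beyond the scatter)), so the halogen carbon matters more here than the methoxy carbon. No measurement shown accounts for either result.

Going by these compounds, whether an amine or a carboxylic acid at the methoxy carbon would stay within the scatter remains open. So does the effect of hydrogen or a nitrile in place of the halogen.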